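Chalcone anilides: one chloro-to-methoxy swap, seen twice

The source may hold more compounds than are shown below. What is called first, only, known or untested is meant among the compounds shown, and "the series" means these compounds.

Compound 1 `CC(Br)C(=O)Nc1ccc(C(=O)/C=C/c2ccc(Cl)cc2)cc1` gives 50% in a functional assay on the whole organism (strain albino) for inhibition, with Rattus norvegicus as the target, read by paw edema, with stated times of 30 min and 5 h, at a dose of 100 mg/kg by the oral route; a higher number here means more inhibition at the dose given (going by the name of the read-out), a lower number less inhibition.
Compound 2 `COc1ccc(/C=C/C(=O)c2ccc(NC(=O)C(C)Br)cc2)cc1` gives 31% in this assay.
Compound 3 `CC(=O)c1ccc(OCC(=O)Nc2ccc(C(=O)/C=C/c3ccc(Cl)cc3)cc2)cc1` gives 55% in this assay.

The change from compound 1 to compound 2 is methoxy in place of chloro on an aromatic carbon, and it made a number 19 percentage points lower from compound 1 to compound 2 (beyond the scatter). Compound 3 carries a different core; the difference between its core and that of compound 1 is not broken down here. Its value lies within the scatter of compound 1 and beyond the scatter of compound 2. Within the data shown here, compound 4 `COc1ccc(/C=C/C(=O)c2ccc(NC(=O)COc3ccc(C(C)=O)cc3)cc2)cc1`, not yet measured, differs from compound 3 by methoxy in place of chloro on an aromatic carbon, which is the same change as the one from compound 1 to compound 2 and sits at a place described in the same words. If this change acts as it did before, compound 4 is expected to show a step of about a number 19 percentage points lower from compound 3 to compound 4 (beyond the scatter), resting on the step from compound 1 to compound 2 a number 19 percentage points lower from compound 1 to compound 2 (beyond the scatter). Compound 4 is therefore estimated at 36%, between 22% and 50%.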

Compound 4, a percentage reported as inhibition, in the whole organism at one dose (the size of the read-out at that dose, not a potency): 30%
Compound 4: the middle estimate sits 6 percentage points above what was measured, within the range that was stated.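

On the second core, methoxy in place of chloro on an aromatic carbon gave, in this assay, a number 25 percentage points lower from compound 3 to compound 4 (beyond the scatter). Set beside the earlier step, the change behaved alike on both cores: the same change on two cores in this assay, a number 19 percentage points lower (beyond the scatter) from compound 1 to compound 2 and a number 25 percentage points lower (beyond the scatter) from compound 3 to compound 4, 6 percentage points apart, within the scatter of two such steps This shows that the change carried over between these two cores in direction and in size, but it rests on only two pairs at a single dose, so it does not show that the same would hold on any other core, nor why the change acts as it does.

The compounds shown leave open how an amine or a hydroxyl on that aromatic carbon would compare with chloro and methoxy. They also leave open whether the step would survive a longer chain on the amide.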